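A few compounds are considered here, and "the series" means these few. Any claim that something is new, unique, unknown or untested is made for them only; others in the source may bear on it.

Compound 1, `CCn1c(N)c(-c2nc3ccccc3[nH]2)c2nc(C#N)c(C#N)nc21`: in a functional assay on HeLa cells (Homo sapiens) for antiproliferative activity, read by MTT assay, with a stated time of 48 h (a higher number here means a weaker inhibitor, a lower number a stronger inhibitor), compound 1 gives > 50000 nM, a limit of the assay and not a number.
Compound 2, `CN(C)CCCn1c(N)c(-c2nc3ccccc3[nH]2)c2nc(C#N)c(C#N)nc21`: in this assay compound 2 gives 25900 nM.
Compound 3, `CCCCn1c(N)c(-c2nc3ccccc3[nH]2)c2nc(C#N)c(C#N)nc21`: in this assay compound 3 gives > 50000 nM, again a limit of the assay.

Compound 3 therefore sits at the limit of > 50000 nM in this assay, at which 2 of the 3 values shown sit, and the step that the two limits leave unreadable from compound 1 to compound 3 cannot be read. For the measured compounds named here, the one readable comparison is an at least 1.9-fold higher number from compound 2 to compound 3 (0.28 log units; that floor lies within the scatter), a change at the same chain carbon.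

Compound 4, `N#Cc1nc2c(-c3nc4ccccc4[nH]3)c(N)n(CCCNc3ccccc3)c2nc1C#N`, is not yet measured. It differs from compound 3 by anilino in place of methyl on a saturated chain carbon, three bonds along the chain from an aromatic nitrogen. Going by the values given here, two measured steps bear on this: an at least 1.9-fold higher number from compound 2 to compound 3 (0.28 log units; that floor lies within the scatter), and, one bond further in, an at least 1.9-fold lower number from compound 1 to compound 2 (0.28 log units; that floor lies within the scatter). Both show that a nitrogen-bearing group on that chain went with a lower number than the plain alkyl, though each only at a floor within the scatter. Compound 4 brings a nitrogen to the same place, so a lower number than the limit of compound 3 is expected, but a modest one: the step of an at least 1.6-fold lower number from compound 3 to compound 4 (0.22 log units; that floor lies within the scatter) is the estimate. Compound 4 is expected to give 30000 nM, within 8000 nM to 50000 nM.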

Compound 4, half-maximal inhibitory concentration: 26300 nM
Beside the measured number, compound 4's estimate is 1.1-fold (0.06 log units) above it; measured number inside the range.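

In this assay, the new anilino group gives an at least 1.9-fold lower number from compound 3 to compound 4 (0.27 log units; that floor lies within the scatter), and read against the shorter chain, anilinomethyl in place of hydrogen gives an at least 1.9-fold lower number from compound 1 to compound 4 (0.27 log units; that floor lies within the scatter); both floors lie within the scatter. Anilino in place of dimethylamino gives a 1.0-fold higher number from compound 2 to compound 4 (0.01 log units; within the scatter), also within the scatter, so a nitrogen carrying a six-membered aromatic ring and one carrying two methyl groups cannot be told apart at this place, which the earlier compounds did not show. Compound 1 and compound 3, the plain alkyl compounds, remain limits of the assay: the limit of > 50000 nM in this assay, at which 2 of the 4 values shown sit.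

The compounds shown leave open whether a phenyl group on the same chain, with no nitrogen, would match compound 4. They also leave open how a piperidine or a longer chain would read here.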